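Cyano in place of butyl: compound 3 to compound 4

The compounds below may be only part of what the source reports. "The series", "measured", "known", "first", "only" and "open" are said of these compounds alone.

Working notes on a small series measured in a functional assay (aorta) with Oryctolagus cuniculus as the target; a higher number here means a weaker inhibitor, a lower number a stronger inhibitor. Compound 1 `OCc1ccc(-c2nn(Cc3ccc(F)cc3)c3ccccc23)o1` gives 19000 nM and compound 2 `OCc1ccc(-c2nn(Cc3ccccn3)c3ccccc23)o1` gives 16000 nM. Going by the values given here, the only single-point step between measured compounds is a 1.2-fold lower number from compound 1 to compound 2 (0.07 log units; within the scatter). Compound 3 `CCCCc1cnc(-c2nn(Cc3ccccc3F)c3ncccc23)nc1N` gives 218000 nM, the highest of the three numbers, beyond the scatter from both compound 1 and compound 2. Compound 4 `N#Cc1cnc(-c2nn(Cc3ccccc3F)c3ncccc23)nc1N` differs from compound 3 by cyano in place of butyl on an aromatic carbon. Among the compounds with values here, no measured step touches this exchange; the one step known concerns another part of the structures and lies within the scatter, so it neither supports nor rules out a shift here. With nothing to lean on, the expected change is a 1.1-fold lower number from compound 3 to compound 4 (0.04 log units; within the scatter), a step not beyond the scatter. Compound 4 is therefore estimated at 200000 nM, with a range from 50000 nM to 800000 nM.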

Compound 4, half-maximal inhibitory concentration: 391000 nM
Compound 4: middle estimate off by 2.0-fold (0.29 log units), on the low side, within the range that was stated.
By their numbers in this assay, from the lowest: compounds 2 and 1 (each within the scatter of the next); then compounds 3 and 4 (each within the scatter of the next).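

Cyano in place of butyl on this aromatic carbon, ortho to an amino group and para to a large group, gives in this assay a 1.8-fold higher number from compound 3 to compound 4 (0.25 log units; within the scatter). Going by these compounds alone, this is the first reading at this position, and it shows that these two groups, which differ in size and in their triple bond, cannot be told apart here. No supporting measurement bears on this result. On these data alone, whether a carboxylic acid, a primary amine or a longer chain on the same carbon would move the number beyond the scatter stays open.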